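A few compounds are considered here, and "the series" means these few. Any claim that something is new, unique, unknown or untested is made for them only; others in the source may bear on it.

Compound 1 `N=C1S/C(=C\c2ccc(OCc3ccccc3)cc2)C(=O)N1c1ccccc1[N+](=O)[O-]`: 24.4%
Compound 2 `N=C1S/C(=C\c2ccc(OCc3ccccc3)cc2)C(=O)N1c1ccc([N+](=O)[O-])cc1`: 17.3%

In an ADME assay on RAW264.7 cells (Mus musculus) for cytotoxicity, read by MTT assay, with a stated time of 48 h, tested at 50 uM (a higher number here means more inhibition at the concentration tested (going by the name of the read-out), a lower number less inhibition), compound 2 gives 17.3%, the lowest of the two numbers, while compound 1 gives 24.4%; the two sit within the scatter of each other, as a number 7.1 percentage points lower from compound 1 to compound 2 (within the scatter) shows. Compound 3 `N=C1S/C(=C\c2ccc(OCc3ccccc3)cc2)C(=O)N1c1ccccn1` differs from compound 2 by pyridin-2-yl in place of 4-nitrophenyl on an amide-type nitrogen in a ring. For the measured compounds named here, the only measured step exchanges one nitrophenyl for another and stays within the scatter; no measured step replaces the ring itself, so no shift beyond the scatter is expected in this assay. Compound 3 is therefore estimated at 20%, between 8% and 34%, an expected step of a number 2.7 percentage points higher from compound 2 to compound 3 (within the scatter).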

Compound 3, a percentage reported as inhibition, at one concentration (the size of the read-out at that concentration, not a potency): 37.2%
For compound 3 the middle estimate is 17.2 percentage points below the measured one; measured number outside the range, above it.
By their numbers in this assay, from the lowest: compounds 2 and 1 (each within the scatter of the next); then compound 3.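

In this assay the position on the amide-type nitrogen proves sensitive to the ring itself: pyridin-2-yl gives a shift beyond the scatter against both nitrophenyl groups (a number 19.9 percentage points higher from compound 2 to compound 3 (beyond the scatter); a number 12.8 percentage points higher from compound 1 to compound 3 (beyond the scatter)). Moving the nitro group alone did not do this. Nothing available explains the shift.

The compounds shown leave open whether the ring nitrogen or the absence of the nitro group drives it. They also leave open how an unsubstituted phenyl ring, or a phenyl ring carrying an amine or a carboxylic acid, would read at this position.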